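Trifluoromethoxy in Place of Chloro: Compound 2 to Compound 3

This account rests on a few compounds, and the source may have more. Where it says the series, first, only, none or still open, it means among the compounds named here.

Of the compounds shown here, two carrying the same core have so far been tested in a functional assay on NCI-H460 cells (Homo sapiens) for antiproliferative activity, read by CCK-8 assay, with a stated time of 72 h, tested at 2 uM; on this read-out higher numbers stand for a stronger effect at the one concentration tested and lower numbers for a weaker effect. Compound 1 `CC(C)n1cnc2c(Nc3cccc(Cl)c3)nc(NCOCc3ccc(C(=O)Nc4ccccc4N)cc3)nc21` gives 28.9% in this assay. Compound 2 `Nc1ccccc1NC(=O)/C=C/c1ccc(Cn2cnc3c(Nc4cccc(Cl)c4)nc(Cl)nc32)cc1` gives 7.11% in this assay, the lower of the two numbers, and its gap to compound 1 lies beyond the usual scatter of such measurements. Among the compounds with values here, no pair of measured compounds differs in only one place, so no measured single step is available to lean on.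

Compound 3 `Nc1ccccc1NC(=O)/C=C/c1ccc(Cn2cnc3c(Nc4cccc(OC(F)(F)F)c4)nc(Cl)nc32)cc1` remains to be measured in this assay. Relative to compound 2 it differs in one place: trifluoromethoxy in place of chloro on an aromatic carbon. Cut one bond further out, the change reads 3-chlorophenyl to 3-(trifluoromethoxy)phenyl. Without a measured step of this kind, the step is expected to be a number 2.9 percentage points higher from compound 2 to compound 3 (within the scatter), most likely no change beyond the scatter. Because compound 2 gives 7.11% in this assay, compound 3 is estimated at 10%, with a range from 0% to 30%.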

Compound 3, a percentage reported as inhibition, at one concentration (the size of the read-out at that concentration, not a potency): 2.1%
Compound 3: middle estimate off by 7.9 percentage points, on the high side; the measured number falls inside the stated range.
By their numbers in this assay, from the lowest: compounds 3 and 2 (each within the scatter of the next); then compound 1.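

In this assay, the first step measured at a single place is a number 5 percentage points lower from compound 2 to compound 3 (within the scatter), so trifluoromethoxy in place of chloro on this aromatic carbon gives a reading that cannot be told apart from that of the chloro compound. Within the data shown here, both numbers are small, with compound 2 at 7.11% and compound 3 at 2.1%, which leaves this read-out at the one tested concentration little room to show any further loss, and the step therefore says only that neither group lifts the effect far at this position on the (3-chlorophenyl)amino part of the molecule. Nothing measured on these compounds speaks to why the two readings stay together.

As far as these compounds go, whether a hydroxyl group, an amine or a carboxylic acid on the same aromatic carbon would move the number beyond the scatter remains open, as does whether any change here would show up on a compound with a stronger starting reading. Compound 1 differs from both others in more than one place, so its reading cannot be assigned to any single part of its structure.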